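Chloro Entering the Core of Compound 1

The source may hold more compounds than are shown below. What is called first, only, known or untested is meant among the compounds shown, and "the series" means these compounds.

Measured compounds:
compound 1, `Nc1scc(-c2cccc(C(F)(F)F)c2)c1C(=O)c1ccccc1`, 61.1%
compound 2, `CCOC(=O)c1c(N)sc(-c2ccc(OC)cc2)c1-c1cccc(C(F)(F)F)c1`, 81.5%
compound 3, `CCOC(=O)c1c(N)sc(-c2ccc(C(F)(F)F)cc2)c1-c1cccc(C(F)(F)F)c1`, 48.5%

In an assay on CHO-K1 cells for displacement of a labelled ligand from adenosine receptor A1 (Homo sapiens), tested at 10 uM (on this read-out lower numbers stand for less inhibition and higher numbers for more inhibition at the one concentration tested (going by the name of the read-out)), compound 1 gives 61.1%, the second highest of the three numbers. Compound 2 gives 81.5%, a number beyond the scatter above it, while compound 3 gives 48.5%, a number beyond the scatter below it. Within the data shown here, the single step among the measured compounds, a number 33 percentage points lower from compound 2 to compound 3 (beyond the scatter), concerns a substituent on a pendant aromatic ring, and compounds 2 and 3 carry an ester and an aryl group on the shared core where compound 1 carries a benzoyl group and a hydrogen, so that step bears only loosely on the change at hand.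

Compound 4, `Nc1sc(Cl)c(-c2cccc(C(F)(F)F)c2)c1C(=O)c1ccccc1`, differs from compound 1 by chloro in place of hydrogen on an aromatic carbon. Among the measured compounds shown here, no measured pair reports a hydrogen replaced by chloro at this place, so the data give no direction for the step. The expected step, a number 2.9 percentage points higher from compound 1 to compound 4 (within the scatter), is therefore one that stays within the scatter. Compound 4 is estimated at 64%, with a range from 44% to 84%.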

Compound 4, a percentage reported as inhibition, at one concentration (the size of the read-out at that concentration, not a potency): 87.1%
The estimate for compound 4 lay 23.1 percentage points below the measured number; the whole stated range lies below it.
By their numbers in this assay, from the lowest: compound 3; then compound 1; then compounds 2 and 4 (each within the scatter of the next).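

In this assay, chloro in place of hydrogen on the aromatic carbon next to the ring sulfur gives a number 26 percentage points higher from compound 1 to compound 4 (beyond the scatter). Among these compounds, this is the first measured step at this place on the core of compound 1, and it shows that the number responds to a change here, even though only one heavy atom enters, with no ring and no net charge. Nothing measured here accounts for the size or direction of this step.

The compounds shown leave open whether bromo, methyl or a nitrile on this carbon would shift the number in the same direction as chloro. They also leave open whether chloro here would give a similar step with an ethyl ester in place of the benzoyl group.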